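Working notes on a myeloperoxidase series: compound 1 toward compound 4

The source may hold more compounds than are shown below. What is called first, only, known or untested is meant among the compounds shown, and "the series" means these compounds.

Measured so far:
compound 1, `CCCc1c[nH]c2ccc(F)cc12`: > 100 nM
compound 2, `NCCCCc1c[nH]c2c(F)cccc12`: 21 nM
compound 3, `NCCCCc1c[nH]c2ccc(C(=O)O)cc12`: "not active" (no number reported)

In an assay on isolated protein for inhibition of Myeloperoxidase (Homo sapiens), read by ELISA, with a stated time of 5 min (a lower number here means a stronger inhibitor, a higher number a weaker inhibitor), compound 1 gives > 100 nM, which is a limit of the assay and not a number. Compound 1 therefore sits at the limit of > 100 nM in this assay, at which 1 of the 3 values shown sits. In this assay compound 2 gives 21 nM. Compound 3 is reported in this assay as "not active" (no number reported).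

Compound 4, `NCC(N)CCc1c[nH]c2ccc(F)cc12`, awaits measurement in this assay. It differs from compound 1 by 1,2-diaminoethyl in place of methyl on a saturated chain carbon, two bonds along the chain from an aromatic carbon. Compound 2 also carries a chain ending in an amine and gives 21 nM. On that basis a step toward stronger inhibition is expected for compound 4, of an at least 2.5-fold lower number from compound 1 to compound 4 (0.39 log units; beyond the scatter), beyond the scatter. Compound 4 is estimated at 40 nM, within 8 nM to 250 nM.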

Compound 4, half-maximal inhibitory concentration: 26 nM
Beside the measured number, compound 4's estimate is 1.5-fold (0.19 log units) above it; the measured number falls inside the stated range.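

In this assay, 1,2-diaminoethyl in place of methyl on a saturated chain carbon, two bonds along the chain from an aromatic carbon, gives an at least 3.8-fold lower number from compound 1 to compound 4 (0.58 log units; beyond the scatter). Within the data shown here, this is the first comparison that differs in one place, and it ties a gain in inhibition to this chain position on the core of compound 1. From the compounds shown here alone, the true size of the step stays open, since compound 1 is held at a limit of the assay: the limit of > 100 nM in this assay, at which 1 of the 4 values shown sits.

Going by these compounds, it remains open whether the step needs both amines, and whether a hydroxyl or an amide on the same chain would give a similar step.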